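The source may hold more compounds than are shown below. What is called first, only, known or untested is meant among the compounds shown, and "the series" means these compounds.

Compounds measured so far:

compound 1, `O=C(/C=C/c1ccc(Cl)cc1)NS(=O)(=O)c1ccccc1` — 2.2 ug/mL
compound 2, `O=C(/C=C/c1ccc(Br)cc1)NS(=O)(=O)c1ccccc1` — 3.9 ug/mL
compound 3, `COc1ccc(/C=C/C(=O)NS(=O)(=O)c2ccccc2)cc1` — 13.2 ug/mL

All three were tested in a functional assay on B16-F10 cells (Mus musculus) for antiproliferative activity, read by ELISA and MTT assay, with a stated time of 48 h; on this read-out lower numbers stand for stronger inhibition and higher numbers for weaker inhibition. They share one core and differ only in the group carried on the ring at the far end, which is where compound 3 carries its methoxy. On the numbers shown, compound 3 stands highest: the step from compound 1 to compound 3 is a 6.0-fold higher number from compound 1 to compound 3 (0.78 log units; beyond the scatter), and the step from compound 2 to compound 3 is a 3.4-fold higher number from compound 2 to compound 3 (0.53 log units; beyond the scatter), both beyond the scatter. Between the two halogen compounds the step is a 1.8-fold higher number from compound 1 to compound 2 (0.25 log units; within the scatter).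

Compound 4, `CN(C)c1ccc(/C=C/C(=O)NS(=O)(=O)c2ccccc2)cc1`, keeps the core of compound 3 and differs from it in one way: dimethylamino in place of methoxy on an aromatic carbon. The two steps that bear on this change are the ones that swapped the group at this same carbon, from chloro or bromo to methoxy, and both raised the number by a modest amount. Going by the values given here, no measured step, however, exchanges methoxy for dimethylamino, so there is no direct guide to its direction. The expectation is therefore a small step in this assay, not beyond the scatter, with the number for compound 4 estimated near that of compound 3: a 1.1-fold higher number from compound 3 to compound 4 (0.06 log units; within the scatter). Compound 4 is expected to give about 15 ug/mL, with a likely range from 6 ug/mL to 35 ug/mL.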

Compound 4, half-maximal inhibitory concentration: 2.3 ug/mL
The estimate for compound 4 lay 6.5-fold (0.81 log units) above the measured number; measured number below the stated range.
By their numbers in this assay, from the lowest: compounds 1, 4 and 2 (each within the scatter of the next); then compound 3.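

Read in this assay, the change from methoxy to dimethylamino on this aromatic carbon gives a 5.7-fold lower number from compound 3 to compound 4 (0.76 log units; beyond the scatter) and so undoes the rise seen on going from the halogens to methoxy, even though the two groups match in their counts of hydrogen-bond donors and acceptors and neither carries a net charge. Dimethylamino also stands level with both halogens, with a 1.7-fold lower number from compound 2 to compound 4 (0.23 log units; within the scatter) and a 1.0-fold higher number from compound 1 to compound 4 (0.02 log units; within the scatter) both inside the scatter, so the earlier steps cannot be read as halogens simply outperforming other groups at this position: among the four groups shown, only methoxy stands apart, with the higher number. No measured property of these compounds is available to account for the gap between methoxy and dimethylamino.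

From the compounds shown here alone, it remains open whether a plain amino group or a hydroxyl on this carbon would fall with compound 3 or with the other three compounds. Going by these compounds, it is also open whether a fluoro group, or a longer ether such as ethoxy, would keep the number low or raise it.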